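Adding a Methoxy Group to the Anilino Ring

The source may report more compounds than this note shows. Statements on the series, on what has been measured and on what is new or still open speak of the compounds shown alone.

Of the compounds shown here, two sharing one core have been tested so far. Compound 1, `Cc1nc(SCC(=O)Nc2nc(-c3ccc(Cl)cc3)cs2)n(Nc2ccccc2)c1C`, was measured in a functional assay on LOX IMVI cells (Homo sapiens) for antiproliferative activity, read by sulforhodamine B assay, with a stated time of 48 h (a lower number here means a stronger inhibitor of growth, a higher number a weaker inhibitor of growth), and gave 1780 nM. Compound 2, `Cc1ccc(Nn2c(SCC(=O)Nc3nc(-c4ccccc4)cs3)nc(C)c2C)cc1`, differs from compound 1 in two places at once. In this assay compound 2 gave 3320 nM. Compound 1 has the lower of the two numbers, yet the two values lie within the scatter of each other, so nothing about order can be read from them.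

Compound 3, `COc1ccc(Nn2c(SCC(=O)Nc3nc(-c4ccc(Cl)cc4)cs3)nc(C)c2C)cc1`, has not yet been measured. It differs from compound 1 in a single place: methoxy in place of hydrogen on an aromatic carbon, on an aromatic carbon of a six-membered aromatic ring of carbon only, para to a large group; the anilino group thus becomes a (4-methoxyphenyl)amino group. Within the data shown here, no measured pair shows what this change does, so the expectation rests on compound 1 alone. Such a change is expected to give at most a small step, a 1.1-fold higher number from compound 1 to compound 3 (0.03 log units; within the scatter), not beyond the scatter, in either direction. Compound 3 is therefore estimated to give 1900 nM, with a likely range from 700 nM to 5000 nM.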

Compound 3, concentration for 50% growth inhibition: 3020 nM
Beside the measured number, compound 3's estimate is 1.6-fold (0.20 log units) below it, within the range that was stated.
By their numbers in this assay, from the lowest: compounds 1, 3 and 2 (each within the scatter of the next).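

Among these compounds, compound 3 gives the first single-change comparison on the anilino ring: in this assay, putting methoxy in place of hydrogen, para to a large group, gives a 1.7-fold higher number from compound 1 to compound 3 (0.23 log units; within the scatter), so this one pair shows no effect on growth inhibition that can be told apart from the ordinary variation between repeated measurements. At this place on the ring, then, a group of 2 heavy atoms, with 1 hydrogen-bond acceptor, is tolerated in this assay, although a small real effect in either direction cannot be ruled out. Nothing among the data given offers an explanation for this result.

Going by these compounds, with only methoxy and hydrogen compared at this place, it remains open whether another group, such as an amine, a carboxylic acid or a longer chain like butoxy, would give a step beyond the scatter. On these data alone, it is also open whether methoxy would behave the same way at another place on this ring, or on a compound that differs from compound 1 elsewhere in its structure.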